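A Methyl Added to Compound 3

The source may report more compounds than this note shows. Statements on the series, on what has been measured and on what is new or still open speak of the compounds shown alone.

Three measured compounds set the background. Compound 1 `CC(=O)c1c(NNc2ccccc2)cc(C)oc1=O` and compound 2 `CC(=O)c1c(NNc2cc(C)c3ccccc3n2)cc(C)oc1=O` share one core, while compound 3 `Cc1cc2nn(-c3ccccc3)c(C)c2c(=O)o1` is built on a different one. In a functional assay on the whole organism for inhibition, with Rattus norvegicus as the target, read by paw edema, with a stated time of 2 h, at a dose of 50 mg/kg (a lower number here means less inhibition, a higher number more inhibition at the dose given (going by the name of the read-out)), compound 1 gives 57.3%. Compound 2 reaches 55.1% in this assay. Compound 3 returns 55.1% in this assay. At the digits shown compound 3 stands level with compound 2, the two together forming the lowest pair of the three numbers; its nearest neighbour is compound 2, with no change at the digits shown, and its furthest is compound 1, whose number lies higher by a gap that still falls within the scatter. Nothing among these three separates itself from the rest.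

Compound 4 `Cc1ccc(-n2nc3cc(C)oc(=O)c3c2C)cc1` differs from compound 3 in one place: methyl in place of hydrogen on an aromatic carbon. Within the data shown here, no pair of measured compounds differing in a single place is available to size such a change, so the expectation rests on the flatness of the three measured numbers and on the small size of the group that enters. The expected step is a number 0.1 percentage points lower from compound 3 to compound 4 (within the scatter), a change of no direction beyond the scatter. Compound 4 is estimated at 55%, within a range from 42% to 68%.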

Compound 4, a percentage reported as inhibition, in the whole organism at one dose (the size of the read-out at that dose, not a potency): 58.4%
For compound 4 the middle estimate is 3.4 percentage points below the measured one, and the stated range covers the measured number.
By their numbers in this assay, from the lowest: compounds 2, 3, 1 and 4 (each within the scatter of the next).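

In this assay the change gives the series its first comparison of two compounds that differ in one place: methyl in place of hydrogen on an aromatic carbon of a six-membered aromatic ring of carbon only, para to a large group, is a number 3.3 percentage points higher from compound 3 to compound 4 (within the scatter). This shows that, on the core of compound 3, this position takes a methyl without a shift beyond the scatter in this read-out, which gives the size of the effect at one dose and not a potency. Nothing available bears on what lies behind this step, so the pair gives its size and no explanation.

This single pair leaves open whether an amine, a carboxylic acid or a longer chain in the same position would also stay within the scatter or would move the number beyond it. It also leaves open whether the same methyl, placed on the phenyl ring of compound 1, would produce a step of similar size on that different core.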